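The source may report more compounds than this note shows. Statements on the series, on what has been measured and on what is new or still open speak of the compounds shown alone.

The series shares the core of compound 1 `COc1ccc(C(=O)Nc2cccc3c2N(S(=O)(=O)c2ccc(OC)cc2)CC3)cc1` and varies the group on the nitrogen on the aromatic ring. In a functional assay on MKN-45 cells (Homo sapiens) for cytotoxicity (on this read-out lower numbers stand for stronger inhibition and higher numbers for weaker inhibition), compound 1 gives 1600 nM, the highest of the three numbers measured. Compound 2 `COc1ccc(S(=O)(=O)N2CCc3cccc(NS(=O)(=O)c4ccccc4)c32)cc1` gives 562 nM and compound 3 `COc1ccc(S(=O)(=O)N2CCc3cccc(NC(C)=O)c32)cc1` gives 61 nM; the steps run a 2.8-fold lower number from compound 1 to compound 2 (0.45 log units; beyond the scatter), a 26-fold lower number from compound 1 to compound 3 (1.42 log units; beyond the scatter) and a 9.2-fold lower number from compound 2 to compound 3 (0.96 log units; beyond the scatter), so every measured step exchanges the whole (4-methoxyphenyl)carbonyl of compound 1 for a smaller group and lowers the number. Compound 4 `COc1ccc(S(=O)(=O)N2CCc3cccc(NC(=O)c4ccc(F)cc4)c32)cc1` keeps the carbonyl and its six-membered aromatic ring of carbon only, and differs from compound 1 only at the far end of that ring: fluoro in place of methoxy on an aromatic carbon. For the measured compounds named here, no measured step alters a substituent on an aromatic carbon para to a large group; the three steps all replace the group on the nitrogen as a whole, and none bears directly on this change. With no guide from the measured compounds, the expectation in this assay for compound 4 is a step not beyond the scatter, a 1.2-fold lower number from compound 1 to compound 4 (0.09 log units; within the scatter). Compound 4 is therefore estimated at 1300 nM, within a range of 450 nM to 3800 nM.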

Compound 4, half-maximal inhibitory concentration: 45 nM
For compound 4 the middle estimate is 29-fold (1.46 log units) above the measured one; measured number outside the range, below it.
By their numbers in this assay, from the lowest: compounds 4 and 3 (each within the scatter of the next); then compound 2; then compound 1.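

In this assay the substituent on the aromatic carbon para to a large group proves decisive: fluoro in place of methoxy gives a 36-fold lower number from compound 1 to compound 4 (1.55 log units; beyond the scatter) while the carbonyl and its ring stay in place. The earlier steps shown here all removed the whole (4-methoxyphenyl)carbonyl, yet a 1.4-fold lower number from compound 3 to compound 4 (0.13 log units; within the scatter) shows that the 4-fluorophenyl group on the carbonyl and the methyl of compound 3 cannot be told apart, and a 12-fold lower number from compound 2 to compound 4 (1.10 log units; beyond the scatter) sets the (4-fluorophenyl)carbonyl clearly ahead of the phenylsulfonyl group. No measurement on hand accounts for the sharp effect of this exchange.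

The compounds shown do not separate a penalty from methoxy on this carbon from a gain from fluoro, since a plain unsubstituted phenyl on the carbonyl is absent from them. As far as these compounds go, whether chloro, methyl, hydroxy or an amine on the same carbon would follow compound 4 or compound 1 also remains open.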